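The compounds below may be only part of what the source reports. "The series", "measured", "known", "first", "only" and "open" are said of these compounds alone.

Compounds 1 to 3 share one core and differ only in one ring attached to it, and all three were tested in an ADME assay on MRC5 cells (Homo sapiens) for cytotoxicity, read by MTT assay, with a stated time of 72 h; a higher number here means that more compound is tolerated, a lower number that less compound is tolerated. In this assay, compound 1 `OC[C@H]1O[C@@H](n2cc(F)c3c(-c4ccco4)ncnc32)[C@H](O)[C@@H]1O`, which carries a furan-2-yl group, gives 29000 nM. Compound 2 `OC[C@H]1O[C@@H](n2cc(F)c3c(-c4ccsc4)ncnc32)[C@H](O)[C@@H]1O`, with thiophen-3-yl instead, gives 50000 nM. Compound 3 `OC[C@H]1O[C@@H](n2cc(F)c3c(-c4nccs4)ncnc32)[C@H](O)[C@@H]1O`, with 1,3-thiazol-2-yl, gives > 50000 nM, which is a limit of the assay and not a number. Its standing is therefore known only as the limit of > 50000 nM in this assay, at which 1 of the 3 values shown sits.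

Compound 4 `OC[C@H]1O[C@@H](n2cc(F)c3c(-c4c[nH]cn4)ncnc32)[C@H](O)[C@@H]1O` has not yet been measured. Its structural change from compound 3 is 1H-imidazol-4-yl in place of 1,3-thiazol-2-yl on an aromatic carbon: one five-membered aromatic ring with 2 hetero atoms replaces another on the same aromatic carbon. Among the compounds with values here, no measured compound carries the entering group, so only the other ring swaps offer a guide. One is a 1.7-fold higher number from compound 1 to compound 2 (0.24 log units; within the scatter), which lies within the scatter. Another is an at least 1.7-fold higher number from compound 1 to compound 3 (0.23 log units; that floor lies within the scatter), whose floor also lies within the scatter. On these data alone, the third is a number no lower from compound 2 to compound 3 (the limit leaves the size open), whose size stays open. A step beyond the scatter is therefore not expected, and the assay may again report only a limit. The expected step is an at least 1.1-fold lower number from compound 3 to compound 4 (0.07 log units; that floor lies within the scatter). For compound 4, the estimate is 42000 nM, with an expected range from 18000 nM to 50000 nM.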

Compound 4, half-maximal cytotoxic concentration: > 50000 nM
Compound 4: no number, only a limit; the forecaster's own chance of this, stated with the estimate: 55%; middle value at least 1.1-fold (0.07 log units) away from the limit.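

In this assay, compound 4 gives only a limit of the assay and not a number, so a ring with 1 hydrogen-bond donor on this aromatic carbon, 1H-imidazol-4-yl, joins 1,3-thiazol-2-yl, which has none, at the same limit: the limit of > 50000 nM in this assay, at which 2 of the 4 values shown sit. The only step that can be read is an at least 1.7-fold higher number from compound 1 to compound 4 (0.23 log units; that floor lies within the scatter), so even with the new ring, the five-membered rings shown are not separated beyond the scatter at this position. The data also show a number no lower from compound 2 to compound 4 (the limit leaves the size open). The steps to compound 4 from compound 2 and from compound 3 cannot be read, and the swap of 1,3-thiazol-2-yl for 1H-imidazol-4-yl therefore has no measured size in either direction.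

On these data alone, how much more compound the cells would tolerate for compound 3 and compound 4 stays open, as the shared limit hides any difference between them. Also open, as far as these compounds go, is whether a group of a different kind on this aromatic carbon, such as an amine, a carboxylic acid or a longer chain, would move the number beyond the scatter.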